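Cytotoxicity of a cyano-for-nitro swap on MT4 cells

The source may report more compounds than this note shows. Statements on the series, on what has been measured and on what is new or still open speak of the compounds shown alone.

Compound 1 `COc1cc2nc(SCC(=O)Nc3ccc(F)cc3)nc(Nc3c(C)cc(/C=C/C#N)cc3C)c2cc1OC` and compound 2 `COc1cc2nc([S+]([O-])CC(=O)Nc3ccccc3[N+](=O)[O-])nc(Nc3c(Cl)cc(/C=C/C#N)cc3Cl)c2cc1OC` share a core and were both tested in an ADME assay on MT4 cells (Homo sapiens) for cytotoxicity, read by MTT assay, with a stated time of 5 days; on this read-out higher numbers stand for lower toxicity in this test and lower numbers for higher toxicity in this test. Compound 1 reaches only a limit of the assay there, giving >= 150000 nM. Compound 2 likewise reaches only a limit, giving > 199000 nM. Neither value is a true number, so compound 2 cannot be ordered against compound 1 on this read-out; both sit at the limits noted in the limit of > 199000 nM in this assay, at which 1 of the 2 values shown sits, and (the limit of >= 150000 nM in this assay, at which 1 of the 2 values shown sits), which is where compound 2 stands among the values shown.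

Compound 3 `COc1cc2nc([S+]([O-])CC(=O)Nc3ccccc3C#N)nc(Nc3c(Cl)cc(/C=C/C#N)cc3Cl)c2cc1OC` has not yet been measured in this assay. It differs from compound 2 by cyano in place of nitro on an aromatic carbon. With no measured step of this kind among the compounds shown, the expected change a step that the limit leaves unreadable from compound 2 to compound 3 is none beyond the scatter, and compound 3 is estimated at 200000 nM, in the range 100000 nM to 400000 nM, most likely again reported only as a limit.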

Compound 3, half-maximal cytotoxic concentration: > 206000 nM
Compound 3 gave a limit, no number; the forecaster's own chance of this, stated with the estimate: 75%; middle value at least 1.0-fold (0.01 log units) away from the limit.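

Compound 2 and compound 3 both reach only a limit of the assay in this assay, so no step can be read between them. The compounds shown leave open whether cyano in place of nitro on an aromatic carbon changes the half-maximal cytotoxic concentration at all.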